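The source may hold more compounds than are shown below. What is called first, only, known or untested is meant among the compounds shown, and "the series" means these compounds.

Among the compounds with values here, compound 2, `O=C(Nc1cc(F)cc2cccnc12)c1cnccn1`, is the smallest of the three measured members, and in a functional assay on MIA PaCa-2 cells (Homo sapiens) for inhibition, read by MTT assay, with a stated time of 72 h (on this read-out lower numbers stand for stronger inhibition and higher numbers for weaker inhibition), compound 2 gives 130 nM. Compound 1, `Cc1cnc(C(=O)Nc2cc(F)cc3cccnc23)cn1`, differs from it by a single change, (methyl in place of hydrogen on an aromatic carbon). That change made the step of a 2.4-fold higher number from compound 2 to compound 1 (0.38 log units; beyond the scatter), so in this assay compound 1 gives 310 nM.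

Compound 3, `CC(C)(C)OC(=O)NCCOc1cc(NC(=O)c2cnccn2)c2ncccc2c1`, carries a different core from compound 2; how the two cores differ is not broken down here. In this assay compound 3 gives 870 nM, the highest of the three measured numbers.

Compound 4, `Cc1cnc(C(=O)Nc2cc(OCCNC(=O)OC(C)(C)C)cc3cccnc23)cn1`, has not yet been measured. It stands to compound 3 exactly as compound 1 stands to compound 2: the difference is methyl in place of hydrogen on an aromatic carbon, and the place described for it is the same, word for word, as the place of the change from compound 2 to compound 1. The change therefore counts as the same change, made a second time, on the core of compound 3 rather than on the core of compound 2.

Within the data shown here, with only one earlier instance of the change to lean on, the expectation for compound 4 rests on that one measured step, a 2.4-fold higher number from compound 2 to compound 1 (0.38 log units; beyond the scatter), applied to the value of compound 3, 870 nM. Compound 4 is expected to show the step of a 2.3-fold higher number from compound 3 to compound 4 (0.36 log units; beyond the scatter), with wide room for error because a single earlier step, a 2.4-fold higher number from compound 2 to compound 1 (0.38 log units; beyond the scatter), is the whole basis. Compound 4 is accordingly estimated at 2000 nM, between 900 nM and 4500 nM.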

Compound 4, half-maximal inhibitory concentration: 670 nM
Compound 4: middle estimate off by 3.0-fold (0.47 log units), on the high side; measured number outside the range, below it.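

In this assay, within the data shown here, placing the methyl on the core of compound 3, which turns pyrazin-2-yl into 5-methylpyrazin-2-yl, gives a 1.3-fold lower number from compound 3 to compound 4 (0.11 log units; within the scatter), so on this core the change leaves no step that can be told from the scatter. The same change therefore did not carry over from the core of compound 2 to the core of compound 3 with the same size, and the two steps differ by more than the scatter of such steps allows: the same change on two cores in this assay, a 2.4-fold higher number (0.38 log units; beyond the scatter) from compound 2 to compound 1 and a 1.3-fold lower number (0.11 log units; within the scatter) from compound 3 to compound 4, 3.1-fold (0.49 log units) apart, beyond the scatter of two such steps This shows that, for these two pairs, the outcome of the methyl depends on the core that carries it, but it does not show which part of the cores is responsible, and two pairs give no rule for any third core.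

The compounds shown leave open whether the step would again differ if the side chain of compound 3 ended in a free amine or a carboxylic acid. They also leave open how an ethyl group or a chlorine atom in place of the methyl would behave on each of the two cores.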